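Sulfonate aryl variation on the shared core: cyano to methylcarbamoyl

This account rests on a few compounds, and the source may have more. Where it says the series, first, only, none or still open, it means among the compounds named here.

Measured compounds:
compound 1 `CNC(=O)c1cccc(S(=O)(=O)Oc2ccc(-c3cncn3C3CCN(C(=O)c4ccc(Cl)c(C(F)(F)F)c4)CC3)cc2)c1` — 1.76 nM
compound 2 `O=C(c1ccc([N+](=O)[O-])cc1)N1CCC(n2cncc2-c2ccc(OS(=O)(=O)c3cccc4cnccc34)cc2)CC1` — 8.29 nM
compound 3 `N#Cc1cccc(S(=O)(=O)Oc2ccc(-c3cncn3C3CCN(C(=O)c4ccc([N+](=O)[O-])cc4)CC3)cc2)c1` — 13 nM

In an assay on THP-1 cells for antagonist activity at P2X purinoceptor 7 (Homo sapiens), read by ELISA, with a stated time of 30 min (on this read-out higher numbers stand for weaker inhibition and lower numbers for stronger inhibition), compound 3 gives 13 nM. Against compound 1, which gives 1.76 nM, compound 3 sits at a higher number by a gap beyond the scatter; against compound 2, which gives 8.29 nM, the gap is within the scatter, so no order between compound 2 and compound 3 is claimed.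

Compound 4 `CNC(=O)c1cccc(S(=O)(=O)Oc2ccc(-c3cncn3C3CCN(C(=O)c4ccc([N+](=O)[O-])cc4)CC3)cc2)c1` is not yet measured. It differs from compound 3 in one place: methylcarbamoyl in place of cyano on an aromatic carbon.

Only one step is shown, a 1.6-fold higher number from compound 2 to compound 3 (0.20 log units; within the scatter), and it exchanges the whole aryl group on the sulfonyl sulfur rather than a substituent on it, so it bears on the present change only loosely and was itself within the scatter. Compound 1 carries the methylcarbamoyl group but also a different benzoyl part, so its value is not a step to compound 4. The expectation is therefore a small shift, a 2.2-fold lower number from compound 3 to compound 4 (0.34 log units; beyond the scatter), toward a lower number, with wide uncertainty.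

Compound 4 is estimated at 6 nM, within 2 nM to 20 nM.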

Compound 4, half-maximal inhibitory concentration: 26 nM
For compound 4 the middle estimate is 4.3-fold (0.64 log units) below the measured one, and the stated range ends below it.
By their numbers in this assay, from the lowest: compound 1; then compounds 2, 3 and 4 (each within the scatter of the next, the first and the last beyond it).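

In this assay, with the 4-nitrobenzoyl part held fixed, the exchange of cyano for methylcarbamoyl gives a 2.0-fold higher number from compound 3 to compound 4 (0.30 log units; within the scatter) and so does not separate the two groups at this position, although the entering group brings a hydrogen-bond donor. Exchange of the whole aryl group on the sulfonyl sulfur does separate two of these compounds, with a 3.1-fold higher number from compound 2 to compound 4 (0.50 log units; beyond the scatter) as a modest step. Going by these compounds alone, with 3-(methylcarbamoyl)phenyl held fixed, the benzoyl part gives the first single-place comparison of that region, and a 15-fold higher number from compound 1 to compound 4 (1.17 log units; beyond the scatter) is the largest step in this set.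

Open, going by these compounds, is whether a carboxylic acid or a primary amine in place of methylcarbamoyl would leave the number within the scatter, and whether cyano would match methylcarbamoyl alongside the 4-chloro-3-(trifluoromethyl)phenyl group. No measurement shown accounts for any of these steps.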